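The compounds below may be only part of what the source reports. "The series", "measured", "known", "first", "only" and "open" are said of these compounds alone.

Three compounds have been measured in an assay on cells for antagonist activity at D(4) dopamine receptor (Homo sapiens), read by luminescence and beta-arrestin recruitment, with a stated time of 90 min; on this read-out higher numbers stand for weaker inhibition and lower numbers for stronger inhibition:

compound 1 `CCc1cccc(NC(=O)CN2CCN(c3ccccn3)CC2)c1`, 370 nM
compound 2 `Cc1cccc(NC(=O)CN2CCN(c3ccc(Cl)cn3)CC2)c1`, 7780 nM
compound 3 `Cc1ccc(C2CCN(CC(=O)Nc3cccc(C)c3)CC2)nc1`, 394 nM

Compound 3 stands second highest of these three numbers. Compound 1 lies nearest to it, within the usual scatter, while compound 2 lies furthest, beyond the scatter. Compound 4 `Cc1cccc(NC(=O)CN2CCC(c3ccccc3)CC2)c1` has not yet been measured. It differs from compound 3 in one place: phenyl in place of 5-methylpyridin-2-yl on a saturated ring carbon. Within the data shown here, no step between measured compounds isolates this change, so the expectation rests on compound 3 alone. The step from compound 3 to compound 4 in this assay is expected to be small, if anything toward a higher number, and not clearly beyond the scatter: a 1.5-fold higher number from compound 3 to compound 4 (0.18 log units; within the scatter). Compound 4 is therefore estimated at 600 nM, with a range from 150 nM to 2500 nM.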

Compound 4, half-maximal inhibitory concentration: 135 nM
Estimate against measurement, compound 4: 4.4-fold (0.65 log units) above, and the stated range ends above it.
By their numbers in this assay, from the lowest: compound 4; then compounds 1 and 3 (each within the scatter of the next); then compound 2.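

In this assay, phenyl in place of 5-methylpyridin-2-yl on the saturated ring carbon gives a 2.9-fold lower number from compound 3 to compound 4 (0.47 log units; beyond the scatter), so this position accepts an aromatic ring of carbon only, without the hydrogen-bond acceptor of the group that leaves. The ring nitrogen and the methyl leave together, and this single step cannot divide the change between them. Nothing available gives a cause for the step. The compounds shown leave open how a chlorine or a methoxy on the phenyl would move the number, and whether plain pyridin-2-yl would stand nearer compound 3 or compound 4.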